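The compounds below may be only part of what the source reports. "The series", "measured", "known", "first", "only" and "open" are said of these compounds alone.

Compound 1 `Cc1cc(=O)oc2cc(OCC(=O)c3ccccc3C(F)(F)F)ccc12`: 43200 nM
Compound 2 `Cc1cc(=O)oc2cc(OCC(=O)c3ccc(C(F)(F)F)cc3)ccc12`: > 100000 nM

Both compounds were tested in a functional assay on MCF7 cells (Homo sapiens) for antiproliferative activity, with a stated time of 96 h; a higher number here means a weaker inhibitor, a lower number a stronger inhibitor. In this assay, for the measured compounds named here, compound 1 gives 43200 nM, and this is the only true number available so far. Compound 2 is recorded at > 100000 nM, which is a limit of the assay and not a number. From the compounds shown here alone, compound 1 therefore has no second measured value to be ranked against, and any comparison with compound 2 remains open-ended.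

The next compound to consider is compound 3 `O=C(COc1ccc2c(C(F)(F)F)cc(=O)oc2c1)c1ccccc1C(F)(F)F`, which differs from compound 1 only on the shared core: trifluoromethyl in place of methyl on an aromatic carbon. In words, trifluoromethyl stands in place of methyl on an aromatic carbon, opposite the ring oxygen. Going by the values given here, no measured pair here shows this exchange, so the data give no direct guide to its effect. The best anchor is compound 1 at 43200 nM. The expected 1.1-fold lower number from compound 1 to compound 3 (0.03 log units; within the scatter) is none beyond the usual scatter, with neither direction favoured. For compound 3 the estimated value is 40000 nM, with an expected range from 15000 nM to 100000 nM.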

Compound 3, half-maximal inhibitory concentration: "not active" (no number reported)
No number was reported for compound 3; no gap can be computed for the estimate.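

For the compounds shown here, compound 3 is recorded as "not active" in this assay, with no number, so no step from compound 1 to compound 3 can be read. Going by these compounds alone, the only limit among the values shown is this: the limit of > 100000 nM in this assay, at which 1 of the 3 values shown sits. The compounds shown leave open how much trifluoromethyl in place of methyl on the shared core changes the result.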